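A few compounds are considered here, and "the series" means these few. Any claim that something is new, unique, unknown or untested is made for them only; others in the source may bear on it.

Working notes on the series. Compound 1 `CC1=C(C)C(=O)C(c2cn([C@H]3C[C@H](O)[C@@H](CO)O3)c(=O)[nH]c2=O)=C(C)C1=O` gives 174000 nM in an ADME assay on L1210/0 cells (Mus musculus) for cytotoxicity, with a stated time of 48 h; a higher number here means a weaker inhibitor, a lower number a stronger inhibitor. Compound 2 `[N-]=[N+]=NCc1cn([C@H]2C[C@H](O)[C@@H](CO)O2)c(=O)[nH]c1=O` gives 124000 nM in this assay, and compound 3 `O=C(CI)NCc1cn([C@H]2C[C@H](O)[C@@H](CO)O2)c(=O)[nH]c1=O` gives 107000 nM. Compound 3 carries the lowest of the three numbers, yet both other compounds lie within the scatter of it, so no ordering is drawn. Going by the values given here, the single measured step, a 1.2-fold lower number from compound 2 to compound 3 (0.06 log units; within the scatter), stayed within the scatter. Compound 4 `CC#Cc1cn([C@H]2C[C@H](O)[C@@H](CO)O2)c(=O)[nH]c1=O` differs from compound 3 by prop-1-yn-1-yl in place of (((iodomethyl)carbonyl)amino)methyl on an aromatic carbon. Among the compounds with values here, no measured step puts prop-1-yn-1-yl onto that aromatic carbon, so the one available step bears only loosely on it; with all three numbers sitting close together, no shift beyond the scatter is anticipated. Compound 4 is therefore expected at 120000 nM, range 40000 nM to 350000 nM. The expected step is a 1.1-fold higher number from compound 3 to compound 4 (0.05 log units; within the scatter).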

Compound 4, half-maximal inhibitory concentration: > 200000 nM
Compound 4: no number, only a limit (the forecaster's own chance of this, stated with the estimate: 15%); middle value at least 1.6-fold (0.22 log units) away from the limit.
By their numbers in this assay, from the lowest: compounds 3, 2 and 1 (each within the scatter of the next). At a limit, above all of these: compound 4.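

In this assay compound 4 is reported only as a limit of the assay: the limit of > 200000 nM in this assay, at which 1 of the 4 values shown sits. Prop-1-yn-1-yl on this aromatic carbon, with no hydrogen-bond donor or acceptor in the group, gives an at least 1.8-fold higher number from compound 3 to compound 4 (0.27 log units; that floor lies within the scatter) and an at least 1.6-fold higher number from compound 2 to compound 4 (0.20 log units; that floor lies within the scatter). As far as these compounds go, these floors show the first result at this position without a number, but they establish no shift beyond the scatter, and the true size of the change remains unknown. From the compounds shown here alone, whether an amine or a carboxylic acid on this carbon would give a step beyond the scatter stays open.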